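Sulfonamide aryl swap in the nitrophenyl-thiazole series

The source may report more compounds than this note shows. Statements on the series, on what has been measured and on what is new or still open speak of the compounds shown alone.

Measured so far:
compound 1 `Nc1ccc(S(=O)(=O)Nc2nc(-c3cccc([N+](=O)[O-])c3)cs2)cc1`, 40 nM
compound 2 `O=[N+]([O-])c1cccc(-c2csc(NS(=O)(=O)c3ccc(Cl)c(Cl)c3)n2)c1`, 120 nM

In an assay on isolated protein for inhibition of kynurenine 3-monooxygenase (Rattus norvegicus) (on this read-out lower numbers stand for stronger inhibition and higher numbers for weaker inhibition), compound 2 gives 120 nM, the higher of the two numbers measured; its nearest neighbour is compound 1, with a 3.0-fold higher number from compound 1 to compound 2 (0.48 log units; beyond the scatter). Compound 3 `COc1ccc(S(=O)(=O)Nc2nc(-c3cccc([N+](=O)[O-])c3)cs2)cc1` is not yet measured. Its change from compound 2 is 4-methoxyphenyl in place of 3,4-dichlorophenyl on a sulfonyl sulfur. Among the measured compounds shown here, the only measured step at this sulfonyl sulfur is a 3.0-fold higher number from compound 1 to compound 2 (0.48 log units; beyond the scatter), where a 4-aminophenyl gave way to the 3,4-dichlorophenyl. For the measured compounds named here, compound 3 returns to a phenyl carrying a single 4-substituent, here 4-methoxyphenyl, which resembles compound 1 more than compound 2 in that respect, but no step with a methoxy group has been measured. The expectation for compound 3 is therefore a modest move back toward the number of compound 1, a 2.0-fold lower number from compound 2 to compound 3 (0.30 log units; within the scatter), with a wide range. Compound 3 is estimated at 60 nM, between 25 nM and 150 nM.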

Compound 3, half-maximal inhibitory concentration: 51 nM
For compound 3 the middle estimate is 1.2-fold (0.07 log units) above the measured one, within the range that was stated.
By their numbers in this assay, from the lowest: compounds 1 and 3 (each within the scatter of the next); then compound 2.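

In this assay the change from the 3,4-dichlorophenyl gives a 2.4-fold lower number from compound 2 to compound 3 (0.37 log units; beyond the scatter) and so shows that the step seen with compound 1 is not confined to the 4-aminophenyl: compound 1 and compound 3, each with a single 4-substituent on the phenyl, both stand beyond the scatter from compound 2. Methoxy in place of amino on an aromatic carbon gives a 1.3-fold higher number from compound 1 to compound 3 (0.11 log units; within the scatter) and so leaves no readable difference between these two groups at this position. Nothing available bears on why the numbers fall this way.

Still open, from the compounds shown here alone, is whether the gap to compound 2 follows from the second chlorine or from the kind of group on the ring, which a 4-chlorophenyl or an unsubstituted phenyl would help to separate. Also open, going by these compounds, is how a carboxylic acid or a longer alkoxy chain such as butoxy would read on this phenyl.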